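Phenoxy swap on the shared core: from compound 1 to compound 4

The source may report more compounds than this note shows. Statements on the series, on what has been measured and on what is new or still open speak of the compounds shown alone.

Compound 1 `Nc1cc(N)c2nc(-c3ccccc3)c(Oc3ccc(Cl)c(Cl)c3)nc2c1` is one of three analogues measured in a functional assay on OVCAR-3 cells (Homo sapiens) for inhibition, read by sulforhodamine B assay, with a stated time of 48 h (a lower number here means a stronger inhibitor of growth, a higher number a weaker inhibitor of growth), where compound 1 gives 10700 nM. It sits at the low end of the three numbers, but compound 3 `CCOC(=O)[C@H](CCC(=O)O)NC(=O)c1ccc(Oc2nc3cc(N)cc(N)c3nc2-c2ccccc2)cc1` with 16200 nM lies within the usual scatter of it; only compound 2 `CCOC(=O)[C@H](CCC(=O)O)NC(=O)c1ccc(CNc2nc3cc(N)cc(N)c3nc2-c2ccccc2)cc1` with 49000 nM stands clearly apart, beyond the scatter. Compound 4 `Nc1cc(N)c2nc(-c3ccccc3)c(Oc3ccc(F)cc3)nc2c1` has not been measured. The change from compound 1 is 4-fluorophenyl in place of 3,4-dichlorophenyl on an oxygen on an aromatic ring. Within the data shown here, no measured pair in the set isolates this change, so the step in this assay is expected to be small and tentative, leaning toward a higher number rather than a lower one, and not far beyond the scatter. The expected step from compound 1 to compound 4 is a 1.7-fold higher number from compound 1 to compound 4 (0.23 log units; within the scatter). For compound 4 the estimate is 18000 nM, within 6000 nM to 55000 nM.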

Compound 4, concentration for 50% growth inhibition: 15500 nM
For compound 4 the middle estimate is 1.2-fold (0.06 log units) above the measured one; measured number inside the range.
By their numbers in this assay, from the lowest: compounds 1, 4 and 3 (each within the scatter of the next); then compound 2.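

In this assay, 4-fluorophenyl in place of 3,4-dichlorophenyl on an oxygen on an aromatic ring gives a 1.4-fold higher number from compound 1 to compound 4 (0.16 log units; within the scatter) and is the only step shown at this position. The two halogenated phenyl groups therefore cannot be told apart here, and this position accepts the change without a step beyond the scatter. Nothing available explains this reading. Still open, on these data alone, is whether unsubstituted phenyl, or a phenyl carrying an amine or a carboxylic acid, would move the number beyond the scatter. Also open, as far as these compounds go, is how methoxy or a longer alkyl chain on that ring would read.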